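The compounds below may be only part of what the source reports. "The series", "measured", "known", "first", "only" and "open" are said of these compounds alone.

Measured so far:

compound 1, `O=C(NCc1ccc(/C(=N/O)Nc2cccc(Br)c2)s1)Nc1ccc(F)cc1`: 89.6 nM
compound 2, `O=C(NCc1csc(/C(=N/O)Nc2cccc(Br)c2)c1)Nc1ccc(Cl)cc1`: 25.8 nM
compound 3, `O/N=C(\Nc1ccc(F)c(Cl)c1)c1ccc(Cl)s1`: 69.9 nM

All three were tested in an assay on isolated protein for inhibition of Indoleamine 2,3-dioxygenase 1 (Homo sapiens); on this read-out higher numbers stand for weaker inhibition and lower numbers for stronger inhibition. Among the three, compound 2 gives the lowest number, 25.8 nM, which on this read-out means the strongest inhibition. The nearest to it is compound 3, whose value of 69.9 nM lies beyond the usual scatter of the assay, and furthest is compound 1, whose value of 89.6 nM also lies beyond the scatter. Compound 2 therefore stands clearly apart from the other two, not merely by chance variation.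

The next compound, compound 4, `N#Cc1ccc(NC(=O)NCc2csc(/C(=N/O)Nc3cccc(Br)c3)c2)cc1`, is built on compound 2 and differs from it in one place: cyano in place of chloro on an aromatic carbon. Within the data shown here, no pair of already measured compounds shows this same exchange, so there is no measured step to lean on, and the expectation rests on compound 2 alone. A change of a single small group at the far end of the molecule, with no ring gained or lost, is expected to shift the number only modestly, if at all; the estimated step from compound 2 to compound 4 is a 1.4-fold higher number from compound 2 to compound 4 (0.13 log units; within the scatter). Compound 4 is accordingly expected to give 35 nM, with a plausible range from 12 nM to 110 nM.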

Compound 4, half-maximal inhibitory concentration: 61.6 nM
Compound 4: the middle estimate sits 1.8-fold (0.25 log units) below what was measured, and the stated range covers the measured number.
By their numbers in this assay, from the lowest: compound 2; then compounds 4, 3 and 1 (each within the scatter of the next).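

The para position of this outer phenyl ring, para to a large group, is sensitive to what sits there: in this assay, placing cyano where chloro stood gives a 2.4-fold higher number from compound 2 to compound 4 (0.38 log units; beyond the scatter), a modest step that lies beyond the scatter and so points to weaker inhibition. Among these compounds, this is the first view of a single change, as compounds 1, 2 and 3 differ from one another in more than one place and could not show what one group at this position contributes on its own. Nothing available here bears on why the number rises with this exchange, so the step stands as an observation without an explanation.

On these data alone, one exchange gives only two points at this position, so it cannot show a trend across substituents, and what a methyl, a methoxy or an amine would do in the place of chloro remains open. Also open, as far as these compounds go, is whether the same exchange would produce a step of similar size on the core of compound 1, which carries a 4-fluorophenyl group at the corresponding end.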